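The source may hold more compounds than are shown below. What is called first, only, known or untested is meant among the compounds shown, and "the series" means these compounds.

Compound 1 `CC(=O)OC[C@H]1O[C@@H](CC(=O)/C=C/c2ccc(NC(=O)Nc3ccccc3)cc2)[C@H](OC(C)=O)[C@@H](OC(C)=O)[C@@H]1OC(C)=O` is one of two measured members of a small set sharing one core. In an ADME assay on Vero cells (Chlorocebus sabaeus) for cytotoxicity, read by resazurin assay, with a stated time of 2 days (a lower number here means that less compound is tolerated, a higher number that more compound is tolerated), compound 1 gives 820000 nM, the highest of the two numbers recorded. Its neighbour compound 2 `CC(=O)OC[C@H]1O[C@@H](CC(=O)/C=C/c2ccc(NC(=S)Nc3ccccc3)cc2)[C@H](OC(C)=O)[C@@H](OC(C)=O)[C@@H]1OC(C)=O` gives 663000 nM in this assay, and the change from the one to the other, a thiocarbonyl in place of a carbonyl within the urea linker, reads a 1.2-fold lower number from compound 1 to compound 2 (0.09 log units; within the scatter); the two compounds cannot be told apart on this number.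

Compound 3 `CC(=O)OC[C@H]1O[C@@H](CC(=O)/C=C/c2ccc(NC(=O)Nc3ccc4ccccc4c3)cc2)[C@H](OC(C)=O)[C@@H](OC(C)=O)[C@@H]1OC(C)=O` is not yet measured. It differs from compound 1 by naphthalen-2-yl in place of phenyl on an amide-type nitrogen. Going by the values given here, no measured step concerns the aryl group on the amide-type nitrogen: the only recorded step alters the urea carbonyl and lies within the scatter, so it says nothing about a larger aromatic group at this position. With nothing in the data to point in either direction, compound 3 is expected to sit near compound 1, and the expected step of a 1.4-fold lower number from compound 1 to compound 3 (0.14 log units; within the scatter) is small, with a wide range to reflect the absence of a guiding comparison. Compound 3 is therefore estimated at 600000 nM, between 250000 nM and 1300000 nM.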

Compound 3, half-maximal cytotoxic concentration: 482000 nM
For compound 3 the middle estimate is 1.2-fold (0.10 log units) above the measured one; measured number inside the range.
By their numbers in this assay, from the lowest: compounds 3, 2 and 1 (each within the scatter of the next).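

Going by these compounds alone, the step of a 1.7-fold lower number from compound 1 to compound 3 (0.23 log units; within the scatter) is the first measured comparison at the aryl group on the amide-type nitrogen. It shows that in this assay, naphthalen-2-yl in place of phenyl, which adds a second six-membered aromatic ring and takes the group from 6 to 10 heavy atoms, leaves the number within the scatter, so compound 3 cannot be told apart from compound 1 here. No measurement beyond these numbers bears on the result, and the data offer no explanation for it.

The compounds shown leave open whether an amine or a carboxylic acid on the aryl group, or cyclohexyl in its place, would carry the number beyond the scatter, since both aromatic groups compared here are plain carbon rings without hydrogen-bond donors or acceptors. They also leave open whether naphthalen-2-yl would read the same alongside the thiocarbonyl of compound 2, and whether free hydroxyl groups in place of the acetates on the shared core would change the picture.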